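Phenyl for Butoxy: An Expected Step in Squalene Synthase Inhibition

The compounds below may be only part of what the source reports. "The series", "measured", "known", "first", "only" and "open" are said of these compounds alone.

Compound 1 `CCCCOc1ccc(OCCCNC(C)C)cc1` is one of three compounds tested in an assay for inhibition of squalene synthase (Rattus norvegicus), using microsomes; on this read-out higher numbers stand for weaker inhibition and lower numbers for stronger inhibition. In this assay compound 1 gives 56 nM. Compound 3 `C=CCc1ccccc1OCCCNC(C)C` gives 56 nM, which matches compound 1 at the digits shown and lies within the scatter; together they stand at the high end of the three numbers. Compound 2 `C=CCc1cc(C(=O)CCC)ccc1OCC(O)CNC(C)C` gives 4.5 nM, a markedly lower number, beyond the scatter. Compound 4 `CC(C)NCCCOc1ccc(-c2ccccc2)cc1` has not yet been measured; it differs from compound 1 by phenyl in place of butoxy on an aromatic carbon. For the measured compounds named here, no measured pair shows this change, so its effect is unknown, and a step of modest size in either direction is expected. The expected step is a 1.4-fold lower number from compound 1 to compound 4 (0.15 log units; within the scatter). Compound 4 is therefore expected to give 40 nM, with a range from 10 nM to 160 nM.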

Compound 4, half-maximal inhibitory concentration: 170 nM
Estimate against measurement, compound 4: 4.3-fold (0.63 log units) below; measured number above the stated range.
By their numbers in this assay, from the lowest: compound 2; then compounds 1 and 3 (each within the scatter of the next); then compound 4.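

In this assay, phenyl in place of butoxy on this aromatic carbon gives a 3.0-fold higher number from compound 1 to compound 4 (0.48 log units; beyond the scatter). For the compounds shown here, this is the first step that can be read at this position, since the earlier compounds offered no pair differing in one place, and it shows that the group held there changes the read-out, with the ring moving it towards weaker inhibition. No measurement at hand accounts for this rise.

The compounds shown leave open how a shorter chain such as methoxy, or a longer one such as hexyloxy, would compare with butoxy on this carbon. They also leave open whether benzyloxy, which carries a phenyl ring on an oxygen-linked chain, would follow butoxy or phenyl.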